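From compound 1 to compound 3: one ring group exchanged

The compounds below may be only part of what the source reports. "The series", "measured", "known", "first", "only" and "open" are said of these compounds alone.

In a physicochemical assay for lipophilicity, using the shake flask method, in phosphate buffer, measured as octanol-water partition, with a stated time of 30 min, at pH 7.4 (a lower number here means a more polar compound, a higher number a more lipophilic compound), compound 1 `Cc1nccn1-c1cnc(NCc2c(F)ccc3c2CCO3)c2cn[nH]c(=O)c12` gives 2.1 as the starting point here. Among the measured compounds shown here, the only other measured compound, compound 2 `CN(C)Cc1ccc(C(=O)Nc2cnc(NCc3c(F)ccc4c3CCO4)n3cnnc23)cc1`, gives 1.8 in this assay and the two values lie within the usual scatter of each other. These two compounds differ in more than one place, so no measured single change is available as a guide.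

Compound 3 `CN(C)C(=O)c1cc(-c2cnc(NCc3c(F)ccc4c3CCO4)c3cn[nH]c(=O)c23)n(C)n1` keeps the core of compound 1 but changes one group 3-(dimethylcarbamoyl)-1-methyl-1H-pyrazol-5-yl in place of 2-methyl-1H-imidazol-1-yl on an aromatic carbon with 3-(dimethylcarbamoyl)-1-methyl-1H-pyrazol-5-yl in place of 2-methyl-1H-imidazol-1-yl on an aromatic carbon. The leaving and entering groups each hold one five-membered aromatic ring with 2 hetero atoms. Only a slight upward change is expected, and the estimated step of a number 0.10 log units higher from compound 1 to compound 3 (within the scatter) would not stand out from the usual scatter. Compound 3 is expected at 2.2 with an estimated range from 1.7 to 2.7 on this scale.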

Compound 3, distribution coefficient: 2.1
Beside the measured number, compound 3's estimate is 0.10 log units above it, within the range that was stated.
By their numbers in this assay, from the lowest: compounds 2, 1 and 3 (each within the scatter of the next).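

Among the compounds shown here, at this aromatic carbon, putting 3-(dimethylcarbamoyl)-1-methyl-1H-pyrazol-5-yl in place of 2-methyl-1H-imidazol-1-yl gives the first single change that can be read, and it shows no change at the digits printed from compound 1 to compound 3 (within the scatter) in this assay for this pair. The entering group holds 11 heavy atoms where the leaving group holds 6, and 3 hydrogen-bond acceptors where the leaving group holds 2, so on this one pair a clearly larger group at this position goes with a reading inside the scatter. Nothing on hand explains why the two groups read alike.

This single pair leaves open whether the same would hold for a group of another kind on this carbon, such as an amine or a carboxylic acid. It also leaves open how the pyrazole ring and its dimethylcarbamoyl part would each read alone.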